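A few compounds are considered here, and "the series" means these few. Any claim that something is new, unique, unknown or untested is made for them only; others in the source may bear on it.

Compound 1 `CNC(=O)c1cccc(NC(=O)N2CCC(Oc3ccccc3Cl)CC2)c1`, compound 2 `CNC(=O)c1cccc(NC(=O)N2CCC(Oc3ccccc3C)CC2)c1` and compound 3 `CNC(=O)c1cccc(NC(=O)N2CCC(Oc3cc(F)ccc3Cl)CC2)c1` share one core and differ only in the aryl group on the ether oxygen. In an assay on isolated protein for inhibition of acyl-CoA desaturase 1 (Mus musculus) (a higher number here means a weaker inhibitor, a lower number a stronger inhibitor), compound 2 gives 17 nM. For compound 1 the value < 4 nM is a limit of this assay rather than a number. For compound 3 the value < 4 nM is likewise a limit. Two of the three values therefore sit at the limit of < 4 nM in this assay, at which 2 of the 3 values shown sit. Among the steps, an at least 4.2-fold higher number from compound 1 to compound 2 (0.62 log units; beyond the scatter), a step that the two limits leave unreadable from compound 1 to compound 3, and an at least 4.2-fold lower number from compound 2 to compound 3 (0.62 log units; beyond the scatter). Compound 4 `CNC(=O)c1cccc(NC(=O)N2CCC(Oc3ccc(F)cc3Cl)CC2)c1` differs from compound 3 by 2-chloro-4-fluorophenyl in place of 2-chloro-5-fluorophenyl on an oxygen on a saturated carbon. Among the measured compounds shown here, no measured step moves the fluorine within the ring, and the fluorine itself enters in an unreadable step, so no step beyond the scatter is anticipated. The expected step is a step that the limit leaves unreadable from compound 3 to compound 4. Compound 4 is thus expected to give 3 nM, between 1 nM and 10 nM.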

Compound 4, half-maximal inhibitory concentration: 6 nM
Compound 4: middle estimate off by 2.0-fold (0.30 log units), on the low side, within the range that was stated.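

Among the compounds shown here, compound 4 carries the first chlorine-bearing aryl group here that reads as a number rather than a limit, so the replacement of 2-methylphenyl now has a size: a 2.8-fold lower number from compound 2 to compound 4 (0.45 log units; beyond the scatter). Moving the fluorine gives an at least 1.5-fold higher number from compound 3 to compound 4 (0.17 log units; that floor lies within the scatter), and adding it at this place gives an at least 1.5-fold higher number from compound 1 to compound 4 (0.17 log units; that floor lies within the scatter), so neither change can yet be called a real loss. Both steps are only floors, set by a limit: the limit of < 4 nM in this assay, at which 2 of the 4 values shown sit.

The compounds shown leave open how far the value of compound 1 or compound 3 truly lies from that of compound 4. They also leave open what a nitrile or a trifluoromethyl in place of the fluoro would give.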